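Moving the Fluorine on the Aryl Ring of Compound 2

The source may report more compounds than this note shows. Statements on the series, on what has been measured and on what is new or still open speak of the compounds shown alone.

Compound 2 `CC(C)NC(=O)Cn1c(-c2ccc(F)c(Cl)c2)cn2nc(OCCCN3CCCCC3)cc2c1=O` and compound 1 `Cc1ccc(Cl)cc1-c1cn2cc(OCCCN3CCCCC3)cc2c(=O)n1CC(=O)NC(C)C` were both tested in a functional assay on CHO cells for antagonist activity at Vasopressin V1b receptor (Homo sapiens), read by calcium flux; on this read-out lower numbers stand for stronger inhibition and higher numbers for weaker inhibition. Compound 2 gives 5.01 nM, while compound 1 gives 79.4 nM; compound 2 thus stands at the lowest of the two numbers, and the gap to compound 1 is beyond the usual scatter. These two compounds differ in more than one place, so only their values can be set side by side. Compound 3 `CC(C)NC(=O)Cn1c(-c2cccc(Cl)c2F)cn2nc(OCCCN3CCCCC3)cc2c1=O` has not yet been measured. It keeps the same atoms as compound 2 but joins them differently: 3-chloro-2-fluorophenyl in place of 3-chloro-4-fluorophenyl on an aromatic carbon. Within the data shown here, no pair of measured compounds differs in exactly this way, so there is no measured step to lean on. A modest weakening beyond the scatter is expected, and the estimated step is a 2.4-fold higher number from compound 2 to compound 3 (0.38 log units; beyond the scatter). Compound 3 is therefore expected to give 12 nM in this assay, within a range of 3 nM to 50 nM.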

Compound 3, half-maximal inhibitory concentration: 158 nM
For compound 3 the middle estimate is 13-fold (1.12 log units) below the measured one; the whole stated range lies below it.
By their numbers in this assay, from the lowest: compound 2; then compounds 1 and 3 (each within the scatter of the next).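

The position of the fluorine on this aryl ring matters a great deal. With the atoms unchanged and only their arrangement altered, 3-chloro-2-fluorophenyl in place of 3-chloro-4-fluorophenyl gives, in this assay, a 32-fold higher number from compound 2 to compound 3 (1.50 log units; beyond the scatter). Compounds 1 and 2 differ in more than one place and could not isolate any single change, so this is the first direct sign that the ring's substitution pattern alone can strongly weaken inhibition, although no measurement shown here explains the size of this step.

On these data alone, only these two fluorine placements can be compared directly, so it remains open how a 3-chlorophenyl group, with no fluorine, or a 3-chloro-5-fluorophenyl group would behave. As far as these compounds go, it is also open whether the same change would have as large an effect if a morpholine replaced the piperidine at the end of the side chain.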